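This account rests on a few compounds, and the source may have more. Where it says the series, first, only, none or still open, it means among the compounds named here.

Compound 1 `O=C(NO)c1ccc(-c2cn([C@H]3C[C@H](C(=O)O)N(CCCc4ccccc4)C3)nn2)cc1`: < 10%
Compound 2 `O=C(NO)c1cccc(-c2cn([C@H]3C[C@H](C(=O)O)N(CCCc4ccccc4)C3)nn2)c1`: < 10%
Compound 3 `O=C(/C=C/c1cn([C@@H]2C[C@@H](C(=O)O)N(CCCc3ccccc3)C2)nn1)NO`: < 10%

In an assay on Sf9 cells for inhibition of histone deacetylase 11 (Homo sapiens), read by fluorescence, tested at 0.5 uM (a higher number here means more inhibition at the concentration tested (going by the name of the read-out), a lower number less inhibition), compound 1 gives < 10%, which is a limit of the assay and not a number. Compound 2 gives < 10%, likewise only a limit. Compound 3 gives < 10%, again a limit rather than a number. The step that the two limits leave unreadable from compound 1 to compound 2 accordingly cannot be sized, and all three results sit at the limit of < 10% in this assay, at which 3 of the 3 values shown sit. Compound 4 `O=C(/C=C/c1cn([C@H]2C[C@H](C(=O)O)N(CCCc3ccccc3)C2)nn1)NO` differs from compound 3 only in configuration: the two compounds have the same atoms and bonds and differ only in configuration as drawn: 2 of 3 stereo elements differ; a stereocentre at a saturated ring carbon is drawn R in compound 3 and S in compound 4; a stereocentre at a saturated ring carbon is drawn S in compound 3 and R in compound 4. Going by the values given here, no measured step bears on a change of configuration, and the results give no number to move from. Compound 4 is therefore expected to remain at the same limit, with a step that the limit leaves unreadable from compound 3 to compound 4 meaning no change beyond the scatter. Compound 4 is estimated at 5%, with a range from 0% to 15%.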

Compound 4, a percentage reported as inhibition, at one concentration (the size of the read-out at that concentration, not a potency): 20%
Beside the measured number, compound 4's estimate is 15 percentage points below it, and the stated range ends below it.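

Changing only the configuration at the two saturated ring carbons gives a number at least 10 percentage points higher from compound 3 to compound 4 (that floor lies within the scatter) in this assay. Putting 2-(hydroxycarbamoyl)ethenyl in place of either hydroxycarbamoylphenyl group gives a number at least 10 percentage points higher from compound 2 to compound 4 (that floor lies within the scatter) and a number at least 10 percentage points higher from compound 1 to compound 4 (that floor lies within the scatter). These are the first steps in the series with a readable floor, though that floor does not by itself clear the usual scatter, and compound 4 alone stands off the shared limit: the limit of < 10% in this assay, at which 3 of the 4 values shown sit.

On these data alone, the true size of each step stays open, since only limits anchor them. Also open, as far as these compounds go, is whether a methyl ester in place of the carboxylic acid would keep the reading of compound 4.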